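The source may hold more compounds than are shown below. What is called first, only, known or untested is meant among the compounds shown, and "the series" means these compounds.

Compound 1 `CCCCNc1nc(N)nc2ccc(OC)cc12` and compound 2 `CCCCNc1nc(N)nc2cc(OC)c(OC)cc12` share one core, and compound 2 carries methoxy in place of hydrogen on an aromatic carbon. In an ADME assay on HEK293 cells (Homo sapiens) for cytotoxicity, with a stated time of 6 h (on this read-out higher numbers stand for lower toxicity in this test and lower numbers for higher toxicity in this test), compound 1 gives > 18000 nM, which is a limit of the assay rather than a number. Compound 2 likewise gives a limit in this assay, > 18000 nM. The step between them, a step that the two limits leave unreadable from compound 1 to compound 2, cannot therefore be read, since the limit of > 18000 nM in this assay, at which 2 of the 3 values shown sit, is where both of these values sit. Compound 3 `CCCCNc1nc(N)nc2cccc(OCc3ccccc3)c12` is built on a second core; how the two cores differ is not broken down here. In this assay, for the measured compounds named here, compound 3 gives 10000 nM, the only number among the three values.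

Compound 4 `CCCCNc1nc(N)nc2cccc(OCc3ccccc3OC)c12` has not yet been measured. It differs from compound 3 by methoxy in place of hydrogen on an aromatic carbon. Going by the values given here, this is the same kind of change as the one made from compound 1 to compound 2, but the surroundings differ: in compound 2 the methoxy sits on a six-membered aromatic ring of carbon only that is part of a fused or bridged system of two rings, ortho to a methoxy group, meta to a fused ring and para to a fused ring, whereas in compound 4 it sits on a six-membered aromatic ring of carbon only, ortho to a large group. Because the measured step that the two limits leave unreadable from compound 1 to compound 2 is unreadable, no size for this change is known from the data. The step expected here, a 1.2-fold higher number from compound 3 to compound 4 (0.08 log units; within the scatter), is small, and it rests only on compound 3 and its value 10000 nM. Compound 4 is accordingly estimated at 12000 nM, between 6000 nM and 25000 nM.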

Compound 4, half-maximal cytotoxic concentration: > 25000 nM
Compound 4 gave a limit, no number; the forecaster's own chance of this, stated with the estimate: 30%; middle value at least 2.0-fold (0.31 log units) away from the limit.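

In this assay, the change from phenyl to 2-methoxyphenyl gives an at least 2.5-fold higher number from compound 3 to compound 4 (0.39 log units; beyond the scatter), so on the core of compound 3 this methoxy goes with a higher number, which on this read-out stands for lower toxicity in this test. Compound 4 gives > 25000 nM, which is a limit of the assay and not a number: the limit of > 25000 nM in this assay, at which 1 of the 4 values shown sits. The result does not show that the change carries from one core to another, since the same kind of change from compound 1 to compound 2 cannot be read, which leaves a single readable step on a single core, with the methoxy of compound 4 ortho to a large group: the limit of > 18000 nM in this assay, at which 2 of the 4 values shown sit.

The compounds shown leave open whether the higher number belongs to methoxy in particular, or whether an amine, a carboxylic acid or a longer chain on an aromatic carbon of the same ring would go with a similar step. They also leave open the true size of the step on the core of compound 3, and whether any step at all appears on the core of compound 1.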